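Acetyl in Place of Hydrogen on the Shared Core

The source may report more compounds than this note shows. Statements on the series, on what has been measured and on what is new or still open speak of the compounds shown alone.

Compound 1 `O=C(CCCCC1CCSS1)NCc1cn(CCCCCOc2ccc3ccc(=O)oc3c2)nn1` and compound 3 `CC(=O)c1cc2ccc(OCCCCCn3cc(CNC(=O)CCCCC4CCSS4)nn3)cc2oc1=O` share one core and differ at a single aromatic carbon. For the measured compounds named here, in a functional assay on PC-12 cells (Rattus norvegicus) for cytotoxicity, read by MTT assay, with stated times of 3 h and 2 h, tested at 1 uM (on this read-out higher numbers stand for a stronger effect at the one concentration tested and lower numbers for a weaker effect), compound 1 gives 57.2%, which is the top of the two numbers so far recorded, though its only companion sits within the scatter of it: in this assay compound 2 `Cc1cc(=O)oc2cc(OCCCCCn3cc(CNC(=O)CCCCC4CCSS4)nn3)ccc12` gives 56.5%.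

The change from compound 1 to compound 3 is acetyl in place of hydrogen on an aromatic carbon.

Going by the values given here, only one measured step bears on this: a number 0.7 percentage points lower from compound 1 to compound 2 (within the scatter), also a replacement of hydrogen on an aromatic carbon of the core, which left the read-out unchanged beyond the scatter. Acetyl is not methyl, and no measured compound carries an acetyl at this place, so that single step is a loose guide rather than a firm one. On its basis the step expected from compound 1 to compound 3 in this assay, a number 2.2 percentage points lower from compound 1 to compound 3 (within the scatter), is none beyond the scatter. Compound 3 is therefore estimated at 55%, with a range from 43% to 67%.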

Compound 3, a percentage reported as activity, at one concentration (the size of the read-out at that concentration, not a potency): 27.4%
For compound 3 the middle estimate is 27.6 percentage points above the measured one; the whole stated range lies above it.
By their numbers in this assay, from the lowest: compound 3; then compounds 2 and 1 (each within the scatter of the next).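

In this assay, acetyl in place of hydrogen on the aromatic carbon two atoms from the ring oxygen gives a number 29.8 percentage points lower from compound 1 to compound 3 (beyond the scatter), so this place on the shared core is not indifferent to substitution. The earlier step, a number 0.7 percentage points lower from compound 1 to compound 2 (within the scatter), with methyl in place of hydrogen on an aromatic carbon, had shown no change beyond the scatter; the new step shows that replacing hydrogen on an aromatic carbon of this core can move the read-out, and that the outcome depends on the group that enters, the place where it enters, or both. Nothing measured here accounts for the size of this step or says what in the acetyl produces it.

The compounds shown do not separate the effect of the group from that of its place, so it remains open whether a methyl, an amine or a carboxylic acid on this same aromatic carbon would lower the read-out as acetyl does, or whether acetyl on another aromatic carbon of the core would do so. Since the read-out comes from a single concentration, the step also leaves open how compound 3 would behave at other concentrations.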